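This account rests on a few compounds, and the source may have more. Where it says the series, first, only, none or still open, it means among the compounds named here.

Working notes on the thiocarbamate series

The series shares the core of compound 1 `CC(C)c1cccc(C(C)C)c1OC(=O)NC(=O)SCc1ccc(Cl)cc1` and varies the group carried on the sulfur. In an assay on microsomes from intestine for inhibition of acyl-CoA:cholesterol acyltransferase (Oryctolagus cuniculus) (on this read-out higher numbers stand for weaker inhibition and lower numbers for stronger inhibition), compound 1 gives 160 nM. Compound 2 `CC(C)c1cccc(C(C)C)c1OC(=O)NC(=O)SCCCc1ccccc1` gives 69 nM in this assay, and compound 3 `CCCCCCCCSC(=O)NC(=O)Oc1c(C(C)C)cccc1C(C)C` gives 160 nM. On these numbers compound 3 stands level with compound 1, the two together being the highest of the three values; the step of no change at the digits printed from compound 1 to compound 3 (within the scatter) is within the scatter, while a 2.3-fold higher number from compound 2 to compound 3 (0.37 log units; beyond the scatter) is beyond it.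

The next compound, compound 4 `CCCCCCCCCCCSC(=O)NC(=O)Oc1c(C(C)C)cccc1C(C)C`, differs from compound 3 by propyl in place of hydrogen on a saturated chain carbon, eight bonds along the chain from a sulfur. Among the compounds with values here, no measured step lengthens the saturated chain on its own, so the closest guide is the exchange no change at the digits printed from compound 1 to compound 3 (within the scatter), where a heptyl chain replaced an aromatic group without moving the number, and a 2.3-fold higher number from compound 2 to compound 3 (0.37 log units; beyond the scatter), which shows that chain and ring groups on the sulfur side stay within a modest range. On that basis, a further lengthening of the chain is expected to bring no step beyond the scatter, a 1.1-fold lower number from compound 3 to compound 4 (0.06 log units; within the scatter). Compound 4 is therefore estimated at 140 nM in this assay, with a range from 50 nM to 400 nM.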

Compound 4, half-maximal inhibitory concentration: 210 nM
Beside the measured number, compound 4's estimate is 1.5-fold (0.18 log units) below it; the measured number falls inside the stated range.
By their numbers in this assay, from the lowest: compound 2; then compounds 1, 3 and 4 (each within the scatter of the next).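

In this assay, within the data shown here, the added propyl gives a 1.3-fold higher number from compound 3 to compound 4 (0.12 log units; within the scatter) as the first reading of chain length alone, so lengthening the saturated chain at this place, eight bonds along the chain from a sulfur, produces no step that can be told from the scatter. Decyl in place of 4-chlorophenyl reads the same way, with a 1.3-fold higher number from compound 1 to compound 4 (0.12 log units; within the scatter) as its step, so compounds 1, 3 and 4 cannot be separated on this read-out even though the groups on the sulfur differ. Only compound 2 stands apart from the other three, and octyl in place of phenyl, with a 3.0-fold higher number from compound 2 to compound 4 (0.48 log units; beyond the scatter) as its step, keeps that gap modest in size while placing the long saturated chain on the same side of it as the shorter one.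

On these data alone, whether a chain longer than that of compound 4, a chain ending in a carboxylic acid or an amine, or a longer chain ending in phenyl would move the number stays open. No measurement on hand accounts for any of these numbers.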